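The source may report more compounds than this note shows. Statements on the series, on what has been measured and on what is new or still open speak of the compounds shown alone.

Measured compounds in an assay on isolated protein for displacement of a labelled ligand from Gonadotropin-releasing hormone receptor (Homo sapiens); a higher number here means a weaker inhibitor, a lower number a stronger inhibitor:
Compound 1, `Cc1nc(CN2CCN(c3cccc4[nH]c(-c5ccc(C(C)(C)C)cc5)nc34)CC2)c[nH]1`, gives 7.5 nM.
Compound 2, `Cc1cc(CN2CCN(c3cccc4[nH]c(-c5ccc(C(C)(C)C)cc5)nc34)CC2)nn1C`, gives 83 nM.
Compound 3, `CCCn1cnc(CN2CCN(c3cccc4[nH]c(-c5ccc(C(C)(C)C)cc5)nc34)CC2)c1C`, gives 12 nM.

All three share one core and differ only in the small ring carried on the saturated chain carbon bound to an amine nitrogen in a ring. Compound 3 holds the second highest of the three numbers; its nearest neighbour is compound 1, since a 1.6-fold higher number from compound 1 to compound 3 (0.20 log units; within the scatter), while compound 2 lies further away, since a 6.9-fold lower number from compound 2 to compound 3 (0.84 log units; beyond the scatter). The remaining measured step, an 11-fold higher number from compound 1 to compound 2 (1.04 log units; beyond the scatter), concerns the same ring swap seen from the other side.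

Compound 4, `CCCCn1cnc(CN2CCN(c3cccc4[nH]c(-c5ccc(C(C)(C)C)cc5)nc34)CC2)c1C`, is the next step: methyl in place of hydrogen on a saturated chain carbon, three bonds along the chain from an aromatic nitrogen; cut one bond further out, this reads as propyl becoming butyl. Within the data shown here, no measured pair changes the length of this chain, so no step speaks to it directly. The closest guide is a 1.6-fold higher number from compound 1 to compound 3 (0.20 log units; within the scatter), where a more extensive change at this ring left the number within the scatter. The two steps beyond the scatter both replace the ring itself rather than lengthen a chain on it. Adding one carbon is therefore expected to give a step of no change at the digits printed from compound 3 to compound 4 (within the scatter) in this assay. Compound 4 is expected to give 12 nM, within 5 nM to 30 nM.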

Compound 4, half-maximal inhibitory concentration: 46 nM
Beside the measured number, compound 4's estimate is 3.8-fold (0.58 log units) below it; the measured number lies above the stated range.
By their numbers in this assay, from the lowest: compounds 1 and 3 (each within the scatter of the next); then compounds 4 and 2 (each within the scatter of the next).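

In this assay, this position turns out to be sensitive to chain length: propyl becoming butyl gives a 3.8-fold higher number from compound 3 to compound 4 (0.58 log units; beyond the scatter) for the addition of a single carbon. Compound 1 and compound 3 had suggested that the ring could carry a propyl chain with little consequence, but the butyl chain brings a 6.1-fold higher number from compound 1 to compound 4 (0.79 log units; beyond the scatter) and so breaks that closeness. The same chain also leaves a 1.8-fold lower number from compound 2 to compound 4 (0.26 log units; within the scatter) as a step within the scatter, showing that one added carbon can matter on the same scale as replacing 2-methyl-1H-imidazol-4-yl with 1,5-dimethyl-1H-pyrazol-3-yl, and nothing given here explains why the longer chain behaves this way.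

With only propyl and butyl compared on this ring, two points cannot establish a trend, and a pentyl chain or a shorter ethyl chain would be needed to show whether the number keeps rising with length or changes abruptly at butyl. On these data alone, it also remains open whether a branched isobutyl group or a cyclopropylmethyl group would behave like propyl or like butyl.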